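Turning one double bond from E to Z in compound 1

A few compounds are considered here, and "the series" means these few. Any claim that something is new, unique, unknown or untested is made for them only; others in the source may bear on it.

Compound 1 `CC/C=C/C/C=C\CC/C=C/C=C/C(=O)NCC(C)(C)O` opens the account. In a functional assay on cells (Platelet, Oryctolagus cuniculus) for inhibition, read by turbidimetry, with a stated time of 3 min, tested at 10 ug/mL (on this read-out lower numbers stand for a stronger effect and higher numbers for a weaker effect at the one concentration tested), compound 1 gives 27.8%, the lowest of the three numbers recorded. Compound 2 `COc1ccc(C2=C(OC(C)=O)Cc3c(OC(C)=O)cc(OC)c(OC)c3O2)cc1` gives 29%, a number that lies within the usual scatter of the value for compound 1. Compound 3 `CCC(=O)CC/C=C\CC/C=C/C=C/C(=O)NCC(C)C` gives 44.2%, which lies beyond that scatter and so shows a weaker effect than compound 1 at the one concentration tested. Compound 4 `CC/C=C\C/C=C\CC/C=C/C=C/C(=O)NCC(C)(C)O` has not yet been measured. It differs from compound 1 as follows: the two compounds have the same atoms and bonds and differ only in configuration as drawn: 1 of 4 stereo elements differ; a double bond is drawn E in compound 1 and Z in compound 4. Among the compounds with values here, no pair of measured compounds separated by a change of this kind is available, so the expectation rests on the smallness of the change alone. The step of a number 2.2 percentage points higher from compound 1 to compound 4 (within the scatter) is expected to stay within the scatter, with no clear direction. Compound 4 is therefore estimated at 30%, in a range from 15% to 46%.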

Compound 4, a percentage reported as activity, at one concentration (the size of the read-out at that concentration, not a potency): 27.8%
For compound 4 the middle estimate is 2.2 percentage points above the measured one; the range from low to high includes it.
By their numbers in this assay, from the lowest: compounds 1, 4 and 2 (each within the scatter of the next); then compound 3.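

In this assay the record shows no change at the digits printed from compound 1 to compound 4 (within the scatter), so turning this one double bond from E to Z leaves the read-out within the scatter at the one concentration tested. This is the first pair in the account that isolates a single change, and it can be read directly because nothing else varies: the fact that compounds 1 and 4 differ only in the configuration as drawn

On these data alone, whether the other double bonds of the chain would behave the same way remains open, as does any difference in effect at other concentrations, which one concentration cannot show. Also open, as far as these compounds go, is how an amine or a carboxylic acid in place of the hydroxyl group would read.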